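Dropping the Methyl from the Benzoyl Ring

The source may hold more compounds than are shown below. What is called first, only, known or untested is meant among the compounds shown, and "the series" means these compounds.

Of the two compounds measured in a functional assay on KB cells (Homo sapiens) for cytotoxicity, read by sulforhodamine B assay, with a stated time of 48 h (a lower number here means a stronger inhibitor, a higher number a weaker inhibitor), compound 1 `CCOC(=O)c1cc2cc(/C=C/C(=O)c3ccc(C)cc3)cc(C(C)CC)c2oc1=O` gives the lower number, 18000 nM. Compound 2 `CCC(C)c1cc(C=O)cc2cc(C(C)=O)c(=O)oc12` gives 176000 nM, a higher number lying beyond the scatter. Compound 3 `CCOC(=O)c1cc2cc(/C=C/C(=O)c3ccccc3)cc(C(C)CC)c2oc1=O` differs from compound 1 only by hydrogen in place of methyl on an aromatic carbon, so that (4-methylphenyl)carbonyl becomes benzoyl. No comparable change has been measured here, so the expected step from compound 1 to compound 3, a 1.2-fold higher number from compound 1 to compound 3 (0.09 log units; within the scatter), is small and within the scatter, in either direction. Compound 3 is therefore estimated at 22000 nM in this assay, with a range from 8000 nM to 60000 nM.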

Compound 3, half-maximal inhibitory concentration: 10500 nM
Compound 3: middle estimate off by 2.1-fold (0.32 log units), on the high side; the range from low to high includes it.
By their numbers in this assay, from the lowest: compounds 3 and 1 (each within the scatter of the next); then compound 2.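

In this assay, the change from 4-methylphenyl to phenyl gives a 1.7-fold lower number from compound 1 to compound 3 (0.23 log units; within the scatter), so this step cannot be told apart from the usual scatter. The methyl on this ring is therefore not needed to keep the activity of compound 1 in this assay. Nothing measured here offers an explanation for this result. The compounds shown compare only methyl and hydrogen at this place on the ring. As far as these compounds go, how an amine, a carboxylic acid or a longer chain there would behave remains open, including whether any of them would move the number beyond the scatter.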